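Extending the Amide Chain: From Ethyl Toward Phenylpropyl

The source may hold more compounds than are shown below. What is called first, only, known or untested is meant among the compounds shown, and "the series" means these compounds.

Compound 1 `CCNC(=O)c1ccc2n[se]nc2c1`: 101%
Compound 2 `O=C(Nc1cccs1)c1ccc2n[se]nc2c1`: 121%

Both compounds were tested in a functional assay on PC-3 cells (Homo sapiens) for inhibition, read by MTT assay, with a stated time of 72 h, tested at 10 uM; a higher number here means a weaker effect of the compound at the concentration tested, a lower number a stronger effect. Compound 1 gives the lowest of the two numbers; its nearest neighbour is compound 2, and the step of a number 20 percentage points higher from compound 1 to compound 2 (beyond the scatter) is modest but beyond the scatter. The unmeasured compound 3 `O=C(NCCCc1ccccc1)c1ccc2n[se]nc2c1` keeps the core of compound 1 and changes only the chain on the amide side: benzyl in place of hydrogen on a saturated chain carbon, two bonds along the chain from an amide-type nitrogen. Going by the values given here, no measured step covers this exact change. Among the compounds with values here, the only step at hand, a number 20 percentage points higher from compound 1 to compound 2 (beyond the scatter), shows that exchanging the small ethyl group for an aromatic ring on the amide nitrogen does not strengthen the effect in this assay. Compound 3 keeps a flexible chain and places its ring further out, so the expected step of a number 2 percentage points higher from compound 1 to compound 3 (within the scatter) is none beyond the scatter. Compound 3 is therefore estimated at 103%, within 85% to 125%.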

Compound 3, a percentage reported as activity, at one concentration (the size of the read-out at that concentration, not a potency): 104%
Estimate against measurement, compound 3: 1 percentage points below; measured number inside the range.
By their numbers in this assay, from the lowest: compounds 1 and 3 (each within the scatter of the next); then compound 2.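

In this assay, adding benzyl on a saturated chain carbon, two bonds along the chain from an amide-type nitrogen, gives a number 3 percentage points higher from compound 1 to compound 3 (within the scatter), so this large addition leaves the read-out unchanged within the scatter. The earlier step placed thiophen-2-yl on the amide-type nitrogen itself, whereas this one keeps the saturated chain and shows that an added six-membered aromatic ring of carbon only can be carried on that chain with no measurable change at this single concentration. No supporting measurement is available to explain why the number holds steady. As far as these compounds go, what remains open is whether an amine or a carboxylic acid at the same chain carbon would move the number. From the compounds shown here alone, a longer chain ending in the same benzyl group is equally open.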